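Swapping a chloropyridine for a methylpyridine: what happens to tolerability

This account rests on a few compounds, and the source may have more. Where it says the series, first, only, none or still open, it means among the compounds named here.

Measured so far:
Compound 1, `CC(CCNC(=O)c1c(Cl)cncc1Cl)N1CCC(C(Oc2ncccc2Cl)c2ccc(C(F)(F)F)cc2)CC1`, gives 16700 nM.
Compound 2, `CCO/N=C(/c1ccc(Br)cc1)C1CCN(C(C)CCN(C)C(=O)c2c(C)cc[n+]([O-])c2C)CC1`, sits at a limit of the assay, > 182000 nM.

Going by the values given here, in an ADME assay on PBMC cells (Homo sapiens) for cytotoxicity (a higher number here means that more compound is tolerated, a lower number that less compound is tolerated), compound 1 gives 16700 nM, and this is the only actual number available. Compound 2 shows only a limit, > 182000 nM, with no number behind it. Among the compounds with values here, there is therefore no measured step between compounds that differ in a single place, and compound 1 stands on its own as the one fixed point.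

Compound 3, `Cc1cccc(OC(c2ccc(C(F)(F)F)cc2)C2CCN(C(C)CCNC(=O)c3c(Cl)cncc3Cl)CC2)n1`, has not yet been measured. Compared with compound 1 it differs in one place: 6-methylpyridin-2-yl in place of 3-chloropyridin-2-yl on an oxygen on a saturated carbon. The rest of the shared core, the amide side chain and the trifluoromethyl-bearing ring are untouched.

Within the data shown here, with no measured step to lean on, the expectation for this assay is that the change moves the read-out little, if at all. The step of a 1.2-fold higher number from compound 1 to compound 3 (0.08 log units; within the scatter) is expected to stay within the usual scatter of repeated measurements. Compound 3 is estimated to give 20000 nM, with a plausible range from 7000 nM to 60000 nM.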

Compound 3, half-maximal cytotoxic concentration: 6700 nM
Beside the measured number, compound 3's estimate is 3.0-fold (0.47 log units) above it, outside the stated range (below it).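

In this assay the swap of 3-chloropyridin-2-yl for 6-methylpyridin-2-yl on the oxygen gives a 2.5-fold lower number from compound 1 to compound 3 (0.40 log units; beyond the scatter) and is the only single-place comparison shown here: less compound is tolerated, by a modest margin that still exceeds what repeated measurements would scatter by. The two groups have the same number of heavy atoms, the same hydrogen-bond donor and acceptor counts and no net charge, so this position is not a silent one, since a swap that leaves those counts unchanged still moves the read-out. Nothing measured here says why the read-out moved.

This single step removes the chlorine and adds the methyl together, and it does not tell which of the two matters, or whether each matters only in combination with the other. Going by these compounds, a plain pyridin-2-yl carrying neither group, or a 3-methylpyridin-2-yl, would pull the two apart, and whether the same step holds with a different amide side chain also stays open.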